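Cytotoxicity on rat muscle cells: amidine versus cyclic amidine

The source may report more compounds than this note shows. Statements on the series, on what has been measured and on what is new or still open speak of the compounds shown alone.

Compound 2 `CC(C)NC(=N)c1ccc2cc(-c3ccc(OCCCCOc4ccccc4)cc3)oc2c1` gives 15900 nM in an ADME assay on L6 cells (Rattus norvegicus) for cytotoxicity, read by resazurin assay, with a stated time of 70 h; a higher number here means a weaker inhibitor, a lower number a stronger inhibitor. For the measured compounds named here, that is the lowest of the two numbers so far, and compound 1 `c1ccc(OCCCOc2ccc(-c3cc4ccc(C5=NCCN5)cc4o3)cc2)cc1` gives 16800 nM, which lies within the scatter of compound 2. Compound 3 `c1ccc(OCCCCOc2ccc(-c3cc4ccc(C5=NCCN5)cc4o3)cc2)cc1` differs from compound 2 by a group of 5 heavy atoms (3 carbon, 2 nitrogen; one five-membered non-aromatic ring with 2 hetero atoms) in place of a group of 6 heavy atoms (4 carbon, 2 nitrogen; no ring), on an aromatic carbon. Compound 1 already carries this ring on the shared core with a shorter chain and sits within the scatter of compound 2, so no step beyond the scatter is expected in this assay here. Compound 3 is therefore estimated at 16000 nM, within 8000 nM to 32000 nM, a step of a 1.0-fold higher number from compound 2 to compound 3 (0.00 log units; within the scatter) that is expected to stay within the scatter.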

Compound 3, half-maximal inhibitory concentration: 16900 nM
Beside the measured number, compound 3's estimate is 1.1-fold (0.02 log units) below it; the measured number falls inside the stated range.
By their numbers in this assay, from the lowest: compounds 2, 1 and 3 (each within the scatter of the next).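

On this aromatic carbon, the five-membered non-aromatic ring with 2 hetero atoms in place of the open group of 6 heavy atoms gives a 1.1-fold higher number from compound 2 to compound 3 (0.03 log units; within the scatter) in this assay, so this exchange, now read with the chain held constant, stays within the scatter. Phenoxymethyl in place of phenoxy on the saturated chain gives a 1.0-fold higher number from compound 1 to compound 3 (0.00 log units; within the scatter), which is also within the scatter with the ring held constant. Nothing available explains either step. Open, as far as these compounds go, is whether a primary amine or a carboxylic acid on this aromatic carbon, or a chain longer than that of compound 3, would move the number beyond the scatter.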